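Shrinking the triazole substituent from fluorophenyl to methyl

The compounds below may be only part of what the source reports. "The series", "measured", "known", "first", "only" and "open" are said of these compounds alone.

Measured so far:
compound 1 `COc1ccc([C@@H]2CC(=O)c3c(O)cc(OCc4cn(Cc5cccc(C(F)(F)F)c5)nn4)cc3O2)cc1O` — 19900 nM
compound 2 `COc1ccc([C@@H]2CC(=O)c3c(O)cc(OCc4cn(Cc5ccccc5F)nn4)cc3O2)cc1O` — 7320 nM

Both compounds were tested in a functional assay on RAW264.7 cells (Mus musculus) for inhibition, read by Griess assay, with stated times of 2 h and 24 h; a lower number here means a stronger inhibitor, a higher number a weaker inhibitor. Within the data shown here, compound 2 has the lowest number of the two, with compound 1 the only neighbour; the step of a 2.7-fold lower number from compound 1 to compound 2 (0.43 log units; beyond the scatter) was gained by trading the 3-(trifluoromethyl)phenyl for a 2-fluorophenyl on the saturated chain carbon bound to an aromatic nitrogen.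

Compound 3 `CCn1cc(COc2cc(O)c3c(c2)O[C@H](c2ccc(OC)c(O)c2)CC3=O)nn1` continues in the same place on the shared core: methyl in place of 2-fluorophenyl on a saturated chain carbon bound to an aromatic nitrogen. Cut one bond further out, the change reads 2-fluorobenzyl to ethyl, so the whole aromatic ring at that position is lost and only a small chain remains.

Among the measured compounds shown here, the single step on record, a 2.7-fold lower number from compound 1 to compound 2 (0.43 log units; beyond the scatter), bears on this only loosely: it shows that a smaller group at this position gave a lower number, but it compares two aromatic rings, not a ring against a methyl. For the measured compounds named here, with no closer precedent, a step in this assay beyond the scatter is not expected in either direction. Compound 3 is therefore estimated at 8000 nM, with a range of 2500 nM to 25000 nM, meaning an expected step of a 1.1-fold higher number from compound 2 to compound 3 (0.04 log units; within the scatter).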

Compound 3, half-maximal inhibitory concentration: 15000 nM
The estimate for compound 3 lay 1.9-fold (0.27 log units) below the measured number; low and high end bracket the measured number.
By their numbers in this assay, from the lowest: compound 2; then compounds 3 and 1 (each within the scatter of the next).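

In this assay, a 2.0-fold higher number from compound 2 to compound 3 (0.31 log units; beyond the scatter) shows that replacing the 2-fluorophenyl with methyl on the saturated chain carbon bound to an aromatic nitrogen is not a neutral change, so this position does respond to more than the earlier pair of aromatic groups could show. The other comparison, a 1.3-fold lower number from compound 1 to compound 3 (0.12 log units; within the scatter), lies within the scatter, so the ethyl of compound 3 and the 3-(trifluoromethyl)benzyl of compound 1 cannot be told apart; an aromatic ring here therefore does not give a lower number by itself, and compound 1 goes against any such rule, while compound 3 shows that the smallest group does not give the lowest number either. Nothing available explains why the three compounds fall as they do.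

From the compounds shown here alone, it remains open whether a plain phenyl, without fluorine, would fall with compound 2 or with compound 1, which would separate the role of the ring from that of its substituent. Where a longer chain such as butyl, or a chain ending in an amine, would fall also remains open.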